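The source may report more compounds than this note shows. Statements on the series, on what has been measured and on what is new or still open speak of the compounds shown alone.

Compound 2 has the structure `O=C(c1ccc(Cl)cc1)N1CCN(c2nc(=O)c3cc(C(F)(F)F)cc([N+](=O)[O-])c3s2)CC1`. In an ADME assay on Vero cells (Chlorocebus sabaeus) for cytotoxicity, read by MTT assay, with a stated time of 72 h (on this read-out lower numbers stand for higher toxicity in this test and higher numbers for lower toxicity in this test), compound 2 gives > 125000 nM, which is a limit of the assay and not a measured number. Its nearest measured neighbour is compound 1, with the structure `O=C(c1ccccc1F)N1CCN(c2nc(=O)c3cc(C(F)(F)F)cc([N+](=O)[O-])c3s2)CC1`, which differs from it only in carrying a 2-fluorophenyl where compound 2 carries a 4-chlorophenyl on a carbonyl carbon. In this assay compound 1 gives > 125000 nM, again a limit rather than a number. The step that the two limits leave unreadable from compound 1 to compound 2 therefore cannot be sized; all that can be said is the limit of > 125000 nM in this assay, at which 2 of the 2 values shown sit.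

Compound 3 has the structure `CC(=O)N1CCN(c2nc(=O)c3cc(C(F)(F)F)cc([N+](=O)[O-])c3s2)CC1`. Its difference from compound 2 is methyl in place of 4-chlorophenyl on a carbonyl carbon. For the measured compounds named here, the only measured step on this carbonyl carbon, from compound 1 to compound 2, gave no readable size, so no direction beyond the scatter can be expected for the step from compound 2 to compound 3; it is estimated as a step that the limit leaves unreadable from compound 2 to compound 3. Compound 3 is therefore expected to give about 150000 nM in this assay, most likely again reported as a limit, with an estimated range from 60000 nM to 400000 nM.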

Compound 3, half-maximal cytotoxic concentration: > 125000 nM
Compound 3 was reported as a limit (the forecaster's own chance of this, stated with the estimate: 75%); the middle value is on the limit's open side.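

Compound 3, like compound 1 and compound 2, gives a limit and not a number, so no step among these three compounds can be read: the limit of > 125000 nM in this assay, at which 3 of the 3 values shown sit. The compounds shown leave open how high their true values lie, and whether any group on the carbonyl carbon would give a number in this assay rather than a limit.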